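The compounds below may be only part of what the source reports. "The series", "measured", "known", "first", "only" and "open" are said of these compounds alone.

In a functional assay on the whole organism with Rattus norvegicus as the target (a lower number here means that less compound is needed, a higher number that more compound is needed for the effect), compound 1 (`Nc1ccc2nc(N)sc2c1`) gives > 10 mg/kg, which is a limit of the assay and not a number. Among the compounds with values here, compound 2 (`Nc1nc2ccc(CC(F)(F)F)cc2s1`), with 2,2,2-trifluoroethyl on the shared core, gives 8 mg/kg, the only actual number so far in this short series. Compound 3 (`Nc1nc2ccc(SC(F)(F)F)cc2s1`) carries (trifluoromethyl)sulfanyl in place of 2,2,2-trifluoroethyl on an aromatic carbon.

Within the data shown here, only one measured step is available, and it bears on this change only indirectly, since it concerns the same 2,2,2-trifluoroethyl group but replaces amino. That step is an at least 1.2-fold lower number from compound 1 to compound 2 (0.09 log units; that floor lies within the scatter). On these data alone, its true size remains open because of the limit of > 10 mg/kg in this assay, at which 1 of the 2 values shown sits. Among the measured compounds shown here, no measured step exchanges the two groups in question, so the data give only weak guidance on size or direction. A modest move towards a lower number is expected in this assay, although no change beyond the scatter would be equally unsurprising. The expected step is a 2.0-fold lower number from compound 2 to compound 3 (0.30 log units; within the scatter). For compound 3 the estimated value is 4 mg/kg, with an expected range of 1.5 mg/kg to 10 mg/kg.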

Compound 3, dose for half-maximal effect: 8 mg/kg
For compound 3 the middle estimate is 2.0-fold (0.30 log units) below the measured one; measured number inside the range.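

In this assay, within the data shown here, the exchange at this aromatic carbon gives no change at the digits printed from compound 2 to compound 3 (within the scatter), the first direct comparison of two groups that both carry a trifluoromethyl end. 2,2,2-trifluoroethyl and (trifluoromethyl)sulfanyl have the same heavy-atom count but differ in the sulfur and in the hydrogen-bond acceptor that enters with it, and that difference leaves the two compounds inseparable in the read-out. Setting (trifluoromethyl)sulfanyl in place of amino gives an at least 1.2-fold lower number from compound 1 to compound 3 (0.09 log units; that floor lies within the scatter), a second step with only a floor, so its true size stays open: the limit of > 10 mg/kg in this assay, at which 1 of the 3 values shown sits.

Among these compounds, compound 2 and compound 3 together cover only two groups of equal heavy-atom count, so it remains open whether a carboxylic acid, a dimethylamino group or a longer chain such as pentyl at this aromatic carbon would move the number beyond the scatter. On these data alone, it also remains open whether either group truly improves on amino, since both steps from compound 1 rest on a floor that lies within the scatter.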